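Swapping the Amine Tail on a Chloro-Benzimidazole Core

The source may hold more compounds than are shown below. What is called first, only, known or untested is meant among the compounds shown, and "the series" means these compounds.

Of the compounds shown here, three have been tested in a functional assay on cells (Homo sapiens) for antiproliferative activity, read by MTT assay, with a stated time of 48 h; a higher number here means a weaker inhibitor, a lower number a stronger inhibitor. Compound 1, with the structure `CN(C)CCCCn1c(N)c(-c2nc3ccccc3n2C)c2nc(C#N)c(C#N)nc21`, gives 1790 nM. Compound 2, with the structure `CCN(CC)CCCCn1c(N)c(-c2nc3ccccc3n2C)c2nc(C#N)c(C#N)nc21`, gives 2890 nM in this assay. Compound 3, with the structure `CN(C)CCCCn1c(N)c(-c2nc3cc(Cl)ccc3[nH]2)c2nc(C#N)c(C#N)nc21`, gives 3280 nM in this assay.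

Compound 2 differs from compound 1 by one change: diethylamino in place of dimethylamino on a saturated chain carbon, four bonds along the chain from an aromatic nitrogen. That change produced a 1.6-fold higher number from compound 1 to compound 2 (0.21 log units; within the scatter), a step that stays within the usual run of repeated measurements. Compound 3 differs from compound 1 in its core: 5-chloro-1H-benzimidazol-2-yl in place of 1-methyl-1H-benzimidazol-2-yl on an aromatic carbon. That core change produced a 1.8-fold higher number from compound 1 to compound 3 (0.26 log units; within the scatter), also within the usual scatter. Compound 3 and compound 2 show numbers that lie within the scatter of each other, so no order can be read between them.

Compound 4, with the structure `CCN(CC)CCCCn1c(N)c(-c2nc3cc(Cl)ccc3[nH]2)c2nc(C#N)c(C#N)nc21`, has not yet been measured. It differs from compound 3 by diethylamino in place of dimethylamino on a saturated chain carbon, four bonds along the chain from an aromatic nitrogen. This is the same change that separates compound 2 from compound 1, made at the same place on the chain, but here on the core of compound 3. Among the compounds with values here, compound 4 is expected to move by a 1.6-fold higher number from compound 3 to compound 4 (0.20 log units; within the scatter) in this assay, a step of about the size of the step from compound 1 to compound 2, because that earlier step of a 1.6-fold higher number from compound 1 to compound 2 (0.21 log units; within the scatter) is the only guide available for this change. Compound 4 is therefore estimated at 5200 nM, with the likely range running from 2500 nM to 11000 nM.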

Compound 4, half-maximal inhibitory concentration: 2840 nM
Beside the measured number, compound 4's estimate is 1.8-fold (0.26 log units) above it; measured number inside the range.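

In this assay, moving from dimethylamino to diethylamino on the chloro-bearing core gives a 1.2-fold lower number from compound 3 to compound 4 (0.06 log units; within the scatter), and exchanging the benzimidazole group while the diethylamino tail stays in place gives a 1.0-fold lower number from compound 2 to compound 4 (0.01 log units; within the scatter). The amine swap therefore shows no detectable dependence on the core, since the two steps for this change stay close enough to be read as the same: the same change on two cores in this assay, a 1.6-fold higher number (0.21 log units; within the scatter) from compound 1 to compound 2 and a 1.2-fold lower number (0.06 log units; within the scatter) from compound 3 to compound 4, 1.9-fold (0.27 log units) apart, within the scatter of two such steps The benzimidazole exchange behaves the same way, but no single step in this set stands clear of the scatter, so the agreement shows only that these small steps do not visibly differ, not that a larger effect would carry unchanged from one core to another: the same change on two cores in this assay, a 1.8-fold higher number (0.26 log units; within the scatter) from compound 1 to compound 3 and a 1.0-fold lower number (0.01 log units; within the scatter) from compound 2 to compound 4, 1.9-fold (0.27 log units) apart, within the scatter of two such steps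

What the compounds shown leave open is whether a clearer step would appear with a different amine at the end of the chain, such as a pyrrolidine or a morpholine, or with a shorter or longer chain. Going by these compounds, it also remains open whether another group on the benzimidazole, such as a fluorine or a methoxy group, would separate the cores in a way that these four compounds cannot.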